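Swapping a nitrogen substituent: compound 2 to compound 3

This account rests on a few compounds, and the source may have more. Where it says the series, first, only, none or still open, it means among the compounds named here.

Measured in a functional assay on DU-145 cells (Homo sapiens) for cytotoxicity, read by trypan blue exclusion, with a stated time of 96 h; a higher number here means a weaker inhibitor, a lower number a stronger inhibitor:
compound 1 `COC(=O)C(Nc1cc(CS(=O)(=O)/C=C/c2c(OC)cc(OC)cc2OC)ccc1OC)c1ccc(F)cc1` gives 300 nM
compound 2 `COC(=O)C(Nc1cc(CS(=O)(=O)/C=C/c2c(OC)cc(OC)cc2OC)ccc1OC)c1ccc(Cl)cc1` gives 400 nM

Within the data shown here, compound 2 stands level with compound 1, the only other compound measured (a 1.3-fold higher number from compound 1 to compound 2 (0.12 log units; within the scatter)). In compound 3 `COc1cc(OC)c(/C=C/S(=O)(=O)Cc2ccc(OC)c(NCCC(=O)O)c2)c(OC)c1`, 2-carboxyethyl sits in place of (4-chlorophenyl)(methoxycarbonyl)methyl on a nitrogen on an aromatic ring (2-carboxyethyl in place of (4-chlorophenyl)(methoxycarbonyl)methyl on a nitrogen on an aromatic ring). Among the measured compounds shown here, the single measured step swaps chloro for fluoro within the group that leaves, so it offers no direct measure of replacing that whole group. With no better guide, no step beyond the scatter is expected (a 1.3-fold higher number from compound 2 to compound 3 (0.10 log units; within the scatter)), though with wide uncertainty in either direction. For compound 3, the estimated value in this assay is 500 nM, with an expected range of 80 nM to 5000 nM.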

Compound 3, half-maximal inhibitory concentration: 5000 nM
The estimate for compound 3 lay 10-fold (1.00 log units) below the measured number; the measured number falls inside the stated range.
By their numbers in this assay, from the lowest: compounds 1 and 2 (each within the scatter of the next); then compound 3.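

In this assay, the substituent on this nitrogen on an aromatic ring matters far more than the chloro or fluoro swap suggested: 2-carboxyethyl gives a large step (a 13-fold higher number from compound 2 to compound 3 (1.10 log units; beyond the scatter)) and the same replacement gives a similar one (a 17-fold higher number from compound 1 to compound 3 (1.22 log units; beyond the scatter)). The change removes the aromatic ring, cuts the group from 12 heavy atoms to 5 and adds a hydrogen-bond donor, all at once, so the shown compounds cannot separate these changes. No evidence here explains the step. Going by these compounds, it remains open whether the carboxylic acid or the lost 4-chlorophenyl ring governs the result. A methyl ester, an amine or a longer chain on this nitrogen could help separate them.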